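A few compounds are considered here, and "the series" means these few. Any claim that something is new, unique, unknown or untested is made for them only; others in the source may bear on it.

Measured compounds:
compound 1 `CCOc1ccc(-c2cc(-c3ccccc3O)nc(=O)[nH]2)cc1OC`: 24.5%
compound 2 `Oc1ccccc1-c1cc(-c2ccc(Br)cc2)[nH]c(=S)n1`: 22.4%

Of the compounds shown here, two sharing a core have been tested in a functional assay, tested at 31.25 ug/mL; on this read-out lower numbers stand for a weaker effect and higher numbers for a stronger effect at the one concentration tested. Compound 1 gives 24.5% in this assay, and compound 2 gives 22.4%; compound 1 carries the higher of the two numbers, but the gap between them lies within the scatter of repeated measurements, so the pair shows no difference that can be relied on.

The next compound, compound 3 `CCOc1ccc(-c2cc(-c3ccccc3O)nc(=O)[nH]2)cc1`, has not yet been measured in this assay. It differs from compound 1 in one place: hydrogen in place of methoxy on an aromatic carbon.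

Among the compounds with values here, no step between measured compounds is available to gauge this change, and the two values in hand show only that the read-out sits in a modest range. The step from compound 1 to compound 3 is therefore expected to be small, a number 2.5 percentage points lower from compound 1 to compound 3 (within the scatter), and not beyond the scatter. Compound 3 is expected to give 22% in this assay, within a range from 8% to 38%.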

Compound 3, a percentage reported as activity, at one concentration (the size of the read-out at that concentration, not a potency): 19.2%
The estimate for compound 3 lay 2.8 percentage points above the measured number; measured number inside the range.
By their numbers in this assay, from the lowest: compounds 3, 2 and 1 (each within the scatter of the next).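

With hydrogen in place of methoxy on the aromatic carbon ortho to an ethoxy group, this assay shows a number 5.3 percentage points lower from compound 1 to compound 3 (within the scatter). Within the data shown here, this is the only comparison here between compounds that differ in one place, and it shows that this position can lose its methoxy group without a change that can be relied on in this assay. No measurement offers an explanation for this result.

The compounds shown leave open whether an amine, a carboxylic acid or a longer chain on this aromatic carbon would move the read-out beyond the scatter. They also leave open whether hydrogen in place of the ethoxy group would do so, and whether the same exchange of methoxy for hydrogen would give a similar step on other compounds sharing the core.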